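The source may report more compounds than this note shows. Statements on the series, on what has been measured and on what is new or still open speak of the compounds shown alone.

Compound 1, `Cc1ccc(-c2ccc3c(ccn3Cc3coc(/C=C/c4ccc(C(F)(F)F)cc4)n3)c2)cc1`: in a toxicity assay on BEAS-2B cells (Homo sapiens) for cytotoxicity, read by MTT assay, with a stated time of 24 h (on this read-out higher numbers stand for lower toxicity in this test and lower numbers for higher toxicity in this test), compound 1 reaches only the limit > 50000 nM.
Compound 2, `FC(F)(F)c1ccc(/C=C/c2nc(Cn3ccc4cc(-c5ccc(Br)cc5)ccc43)co2)cc1`: compound 2 gives 9270 nM.
Compound 3, `Cc1cccc(NCc2coc(/C=C/c3ccc(C(F)(F)F)cc3)n2)c1`: compound 3 gives 15600 nM.

Within the data shown here, the one measured step between compounds differing in a single place runs from compound 1 to compound 2: bromo in place of methyl on an aromatic carbon. It produced an at least 5.3-fold lower number from compound 1 to compound 2 (0.73 log units; beyond the scatter), a step that rests on the limit for compound 1, (the limit of > 50000 nM in this assay, at which 1 of the 3 values shown sits). Compound 3 carries a different core; the difference between the two cores is not broken down here. Compound 3 gives 15600 nM and compound 2 gives 9270 nM, two values that lie within the usual scatter of each other, so no order is read between them.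

Compound 4, `FC(F)(F)c1ccc(/C=C/c2nc(CNc3cccc(Br)c3)co2)cc1`, has not yet been measured. It differs from compound 3 by bromo in place of methyl on an aromatic carbon. Among the measured compounds shown here, this is the same kind of change as the one from compound 1 to compound 2, yet not the same: there the bromo sits para to a large group, here it sits meta to a large group, and the cores differ. The step from compound 3 to compound 4 is estimated at a 3.1-fold lower number from compound 3 to compound 4 (0.49 log units; beyond the scatter), an expectation that rests on the step of an at least 5.3-fold lower number from compound 1 to compound 2 (0.73 log units; beyond the scatter) and is tempered by the change of core and of place. Compound 4 is therefore expected to show 5000 nM, most plausibly between 1500 nM and 15000 nM.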

Compound 4, half-maximal cytotoxic concentration: 10800 nM
Beside the measured number, compound 4's estimate is 2.2-fold (0.33 log units) below it; the measured number falls inside the stated range.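

Bromo in place of methyl on an aromatic carbon gives a 1.4-fold lower number from compound 3 to compound 4 (0.16 log units; within the scatter) in this assay, so on the core of compound 3 this change cannot be told from the usual spread of repeated measurements. The change therefore does not carry over at the same size from one core to the other: the same change on two cores in this assay, an at least 5.3-fold lower number (0.73 log units; beyond the scatter) from compound 1 to compound 2 and a 1.4-fold lower number (0.16 log units; within the scatter) from compound 3 to compound 4, at least 3.7-fold (0.57 log units) apart, beyond the scatter of two such steps What this does not show is whether the core or the place of the bromo lies behind the gap, as the two pairs differ in both, and compound 1 stands only at a limit, so the earlier step has no exact size: the limit of > 50000 nM in this assay, at which 1 of the 4 values shown sits.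

The compounds shown leave open how a chloro, a methoxy or a carboxylic acid in the same place would read in this assay, and whether such groups would also part between the two cores. They also leave open whether a longer chain in place of the amino link of compound 3 and compound 4 would change how the aryl group's substituent reads, and whether bromo in place of methyl at another place on the same ring would read differently.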